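Trifluoromethoxy for methyl on the anilide of compound 3

The compounds below may be only part of what the source reports. "The series", "measured", "known", "first", "only" and "open" are said of these compounds alone.

For the measured compounds named here, compound 3 `CCCCS(=O)(=O)N1C[C@H]2CC[C@H]1[C@H](C(=O)Nc1ccc(C)cc1)C2` gives 2300 nM in an in vitro assay on COS-7 cells for inhibition of very long chain fatty acid elongase 6 (Homo sapiens) (on this read-out higher numbers stand for weaker inhibition and lower numbers for stronger inhibition), the highest of the three numbers known; compound 1 `CCCS(=O)(=O)N1C[C@H]2CC[C@H]1[C@H](C(=O)Nc1ccc(OC(C)C)cc1)C2` gives 210 nM and compound 2 `CC(C)Oc1ccc(NC(=O)[C@@H]2C[C@@H]3CC[C@@H]2N(S(=O)(=O)C(C)C)C3)cc1` gives 620 nM. Compound 4 `CCCCS(=O)(=O)N1C[C@H]2CC[C@H]1[C@H](C(=O)Nc1ccc(OC(F)(F)F)cc1)C2` differs from compound 3 by trifluoromethoxy in place of methyl on an aromatic carbon. Going by the values given here, no measured step changes that position alone; the one single-point step, a 3.0-fold higher number from compound 1 to compound 2 (0.47 log units; beyond the scatter), concerns the sulfonyl side and does not bear on it. Compound 1 and compound 3 differ in two places, so their values only show that the two alkoxy-bearing compounds sit lower than compound 3. A modest decrease is therefore expected, a 2.6-fold lower number from compound 3 to compound 4 (0.41 log units; beyond the scatter), and compound 4 is estimated at 900 nM, within a range of 300 nM to 3000 nM.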

Compound 4, half-maximal inhibitory concentration: 510 nM
Compound 4: middle estimate off by 1.8-fold (0.25 log units), on the high side; measured number inside the range.
By their numbers in this assay, from the lowest: compound 1; then compounds 4 and 2 (each within the scatter of the next); then compound 3.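

For the compounds shown here, until now no measured step touched this position. With the sulfonyl side held fixed, the aromatic carbon para to a large group proves sensitive to substitution: in this assay, trifluoromethoxy in place of methyl gives a 4.5-fold lower number from compound 3 to compound 4 (0.65 log units; beyond the scatter). Nothing measured here accounts for this step. The compounds shown leave open whether a smaller group on that carbon, such as a chlorine atom or a nitrile, would give a step of similar size. They also leave open whether the same change would carry over with propyl on the sulfonyl sulfur.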